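The compounds below may be only part of what the source reports. "The series", "measured", "known", "first", "only" and "open" are said of these compounds alone.

Measured in an ADME assay on BAEC cells (Bos taurus) for cytotoxicity, read by MTT assay, with a stated time of 2 days; on this read-out higher numbers stand for weaker inhibition and lower numbers for stronger inhibition:
Compound 1 `COc1c(Br)cc(C=O)c(O)c1Br` gives 806000 nM
Compound 2 `COc1c(Br)cc(CO)c(O)c1Br` gives > 16000 nM, which is a limit
Compound 3 `COc1c(Br)cc(CO)c(OCCO)c1Br` gives > 28000 nM, which is a limit

Compound 2 has no exact number, only the limit > 16000 nM, so its place among the three compounds cannot be fixed. The step to compound 4 `COC(=O)CCc1cc(Br)c(OC)c(Br)c1O` puts (methoxycarbonyl)methyl in place of hydroxy on a saturated chain carbon bound to an aromatic carbon, as counted in (methoxycarbonyl)methyl in place of hydroxy on a saturated chain carbon bound to an aromatic carbon. Going by the values given here, two measured steps bear on this change, and neither has a readable size. One is a step that the limit leaves unreadable from compound 1 to compound 2 and the other is a step that the two limits leave unreadable from compound 2 to compound 3. They offer no size or direction to carry over. Among the compounds with values here, the only exact number is that of compound 1, 806000 nM, so weak inhibition is also expected for compound 4 in this assay. The estimated step is a step that the limit leaves unreadable from compound 2 to compound 4. For compound 4 the expected value is 80000 nM, with an estimated range from 20000 nM to 500000 nM.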

Compound 4, half-maximal inhibitory concentration: 136000 nM
Compound 4: the middle estimate sits 1.7-fold (0.23 log units) below what was measured, within the range that was stated.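

Compound 2 stands only as a limit, > 16000 nM, so no size can be read for its step to compound 4. The compounds shown leave open whether (methoxycarbonyl)methyl in place of hydroxy strengthens or weakens inhibition, and by how much.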